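This account rests on a few compounds, and the source may have more. Where it says the series, first, only, none or still open, it means among the compounds named here.

Going by the values given here, in a functional assay on NCI-H146 cells (Homo sapiens) for cytotoxicity, with a stated time of 48 h, in the presence of a further agent that is not named here (on this read-out higher numbers stand for an effect only at larger amounts of compound and lower numbers for an effect already at smaller amounts), compound 1 `Cc1cc(S(=O)(=O)NC(=O)c2ccc(N3CCN(Cc4ccccc4-c4ccc(Cl)cc4)CC3)cc2)ccc1N[C@H](CCN(C)C)CSc1ccccc1` gives 28800 nM, the highest of the three numbers so far. Compound 2 `CN(C)CC[C@H](CSc1ccccc1)Nc1ccc(S(=O)(=O)NC(=O)c2ccc(N3CCN(CC4=C(c5ccc(Cl)cc5)CCC4)CC3)cc2)cc1[N+](=O)[O-]` gives 691 nM and compound 3 `CN(C)CC[C@H](CSc1ccccc1)Nc1ccc(S(=O)(=O)NC(=O)c2ccc(N3CCN(CC4=C(c5ccc(Cl)cc5)CCOC4)CC3)cc2)cc1[N+](=O)[O-]` gives 266 nM, both lower than compound 1 by margins well beyond the scatter. Compound 4 `CN(C)CC[C@H](CSc1ccccc1)Nc1ccc(S(=O)(=O)NC(=O)c2ccc(N3CCN(Cc4ccccc4-c4ccc(Cl)cc4)CC3)cc2)cc1C(=O)C(F)(F)F` is not yet measured. It keeps the rest of compound 1 and carries one change, (trifluoromethyl)carbonyl in place of methyl on an aromatic carbon.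

Among the compounds with values here, no step between measured compounds isolates a change in one place, so the evidence is indirect. Compound 2 at 691 nM and compound 3 at 266 nM also lack this methyl, but both differ from compound 1 elsewhere as well. A large step towards a lower number is therefore expected in this assay, with considerable uncertainty about its size. The expected change is a 36-fold lower number from compound 1 to compound 4 (1.56 log units; beyond the scatter). For compound 4 the estimated value is 800 nM, within an expected range of 200 nM to 5000 nM.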

Compound 4, half-maximal effective concentration: 2010 nM
Beside the measured number, compound 4's estimate is 2.5-fold (0.40 log units) below it; low and high end bracket the measured number.
By their numbers in this assay, from the lowest: compound 3; then compound 2; then compound 4; then compound 1.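

In this assay, going by these compounds alone, the step from methyl to (trifluoromethyl)carbonyl gives a 14-fold lower number from compound 1 to compound 4 (1.16 log units; beyond the scatter), the first comparison in which only this aromatic carbon changes. The substituent here, ortho to a large group and meta to a large group, is therefore enough on its own to shift the read-out beyond the scatter, with the rest of compound 1 held constant. No accompanying measurement bears on the reason for this step.

From the compounds shown here alone, whether a nitrile, a carboxylic acid or an amine on this aromatic carbon would give a lower or higher number remains open. Also open, going by these compounds, is whether a step of this size would recur when the rest of the structure differs from compound 1.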